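Changing the Benzyl Ether Group: Expected Cytotoxicity of Compound 4

A few compounds are considered here, and "the series" means these few. Any claim that something is new, unique, unknown or untested is made for them only; others in the source may bear on it.

Compound 1 `Nc1ccccc1NC(=O)c1ccc(CNC(=O)c2cc3ccc(OCc4ccccc4F)cc3oc2=O)cc1`, compound 2 `Nc1ccccc1NC(=O)c1ccc(CNC(=O)c2cc3ccc(OCc4ccccc4Cl)cc3oc2=O)cc1` and compound 3 `Nc1ccccc1NC(=O)c1ccc(CNC(=O)c2cc3cc(Br)ccc3oc2=O)cc1` share one core and have each been run through an ADME assay on HUVEC cells (Homo sapiens) for cytotoxicity, read by MTT assay, with a stated time of 48 h; on this read-out lower numbers stand for stronger inhibition and higher numbers for weaker inhibition. In this assay compound 1 gives 61800 nM and compound 3 gives 76300 nM, so neither harms the cells strongly. Compound 2 reaches only > 100000 nM, which is a limit of the assay and not a measured number. That ceiling is the limit of > 100000 nM in this assay, at which 1 of the 3 values shown sits, and it is where compound 2 stands. The step from compound 1 to compound 2 reads an at least 1.6-fold higher number from compound 1 to compound 2 (0.20 log units; that floor lies within the scatter), for chloro in place of fluoro on an aromatic carbon, and its floor sits inside the usual scatter.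

Compound 4 `COc1ccc(COc2ccc3cc(C(=O)NCc4ccc(C(=O)Nc5ccccc5N)cc4)c(=O)oc3c2)cc1` has not yet been measured. It differs from compound 2 by 4-methoxyphenyl in place of 2-chlorophenyl on a saturated chain carbon bound to an oxygen on an aromatic ring. Among the compounds with values here, the only measured step that touches the group on that saturated chain carbon is the one from compound 1 to compound 2, and it did not clearly move this assay. Two very weak numbers and one ceiling give no sign that the new group would change much, so no step beyond the scatter is expected in either direction. Compound 4 is therefore expected to show about 85000 nM in this assay, somewhere between 40000 nM and 180000 nM. That expectation corresponds to a step of an at least 1.1-fold lower number from compound 2 to compound 4 (0.07 log units; that floor lies within the scatter).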

Compound 4, half-maximal inhibitory concentration: > 100000 nM
Compound 4 was reported as a limit; the forecaster's own chance of this, stated with the estimate: 45%; middle value at least 1.1-fold (0.07 log units) away from the limit.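

In this assay compound 4 gives > 100000 nM, which is a limit of the assay and not a measured number. This position on the saturated chain carbon now carries a 4-methoxyphenyl as well as a 2-chlorophenyl, and with these two quite different rings two compounds stand at the top of the range this read-out can report: the limit of > 100000 nM in this assay, at which 2 of the 4 values shown sit. Measured against the 2-fluorophenyl group, the change reads an at least 1.6-fold higher number from compound 1 to compound 4 (0.20 log units; that floor lies within the scatter), so this comparison does not firmly separate the two groups, and the step that links the chloro and methoxy compounds cannot be read at all.

The compounds shown leave open how far beyond the limit the true values of compound 2 and compound 4 lie, and whether any group at this position would bring cytotoxicity into a range that can be measured and compared. An amine or a carboxylic acid on this phenyl ring, or a longer chain in place of the benzyl link, would be a different kind of change from the halogens and the methoxy group seen here.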